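Hydroxyphenyl-substituted pyridine triaryls: position swap notes

The source may hold more compounds than are shown below. What is called first, only, known or untested is meant among the compounds shown, and "the series" means these compounds.

Measured so far:
- compound 1, `Oc1cccc(-c2cc(-c3cccc(F)c3)cc(-c3ccccc3O)n2)c1`: > 50000 nM
- compound 2, `Oc1ccc(-c2cc(-c3cccc(F)c3)cc(-c3ccccc3O)n2)cc1`: > 50000 nM
- compound 3, `Oc1ccc(-c2cc(-c3ccc(OC(F)(F)F)cc3)cc(-c3cccc(O)c3)n2)cc1`: 1380 nM

In a functional assay on HCT-15 cells (Homo sapiens) for inhibition (on this read-out higher numbers stand for weaker inhibition and lower numbers for stronger inhibition), compound 1 reaches only the limit of the assay, > 50000 nM. Compound 2 likewise sits at the limit, > 50000 nM. The step that the two limits leave unreadable from compound 1 to compound 2 therefore cannot be read; the change is 4-hydroxyphenyl in place of 3-hydroxyphenyl on an aromatic carbon. Compound 3 is the only one of the three with a number in this assay, 1380 nM. How the core of compound 3 differs from the core of compound 1 is not broken down here.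

Compound 4, `Oc1ccc(-c2cc(-c3ccc(OC(F)(F)F)cc3)cc(-c3ccc(O)cc3)n2)cc1`, has not yet been measured in this assay. It differs from compound 3 by 4-hydroxyphenyl in place of 3-hydroxyphenyl on an aromatic carbon. This is the same kind of change as that from compound 1 to compound 2, but the surroundings of the place differ: in the first pair the site is meta to a 2-hydroxyphenyl group and meta to a 3-fluorophenyl group, in the second pair it is meta to a 4-hydroxyphenyl group and meta to a large group. Because (the limit of > 50000 nM in this assay, at which 2 of the 3 values shown sit), the earlier step gives no readable size to carry over.

With no readable precedent, the expected step of a 1.1-fold higher number from compound 3 to compound 4 (0.04 log units; within the scatter) is taken as small, resting only on the value of compound 3, 1380 nM, and on the shared atoms of the two structures. Compound 4 is expected to give about 1500 nM in this assay, within a wide range from 300 nM to 8000 nM.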

Compound 4, half-maximal inhibitory concentration: 13900 nM
Estimate against measurement, compound 4: 9.3-fold (0.97 log units) below; the measured number lies above the stated range.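

In this assay, 4-hydroxyphenyl in place of 3-hydroxyphenyl gives a 10-fold higher number from compound 3 to compound 4 (1.00 log units; beyond the scatter), so in the core of compound 3 this change weakens inhibition by more than the usual scatter of repeated measurements. The same change has no readable size from compound 1 to compound 2, because both compounds stand at a limit of the assay and not at a number: the limit of > 50000 nM in this assay, at which 2 of the 4 values shown sit. The series therefore offers one readable instance of this change, which shows that it can matter in one core but does not show that its direction or size carries over to another, and nothing here establishes why compound 4 is the weaker of the pair.

On these data alone, whether the step recurs remains open for a core that gives numbers on both sides of the change, including cores that keep the 3-fluorophenyl group but sit clear of the limit. Also open, as far as these compounds go, is what happens in this assay when an amine or a carboxylic acid stands in place of the hydroxyl group on the 3-hydroxyphenyl or 4-hydroxyphenyl ring, which would test whether the step belongs to the hydroxyl group or to the ring carrying it.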